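Removing the Piperidinyl Group from a Sulfamate Amide

The compounds below may be only part of what the source reports. "The series", "measured", "known", "first", "only" and "open" are said of these compounds alone.

Measured so far:
compound 1, `NS(=O)(=O)Oc1ccc2c(c1)CN(C(=O)c1cccc(N3CCN(c4ncccn4)CC3)c1)CC2`, 1.6%
compound 2, `NS(=O)(=O)Oc1ccc2c(c1)CN(C(=O)c1ccc(N3CCC(N4CCCCC4)CC3)cc1)CC2`, 8.5%
compound 3, `CN(C)CCCN(Cc1ccccc1)c1cccc(C(=O)N2CCc3ccc(OS(N)(=O)=O)cc3C2)c1`, 23.8%

Of the compounds shown here, three sharing a sulfamate-bearing core have been tested in an assay on HEK293 cells for inhibition of Steryl-sulfatase (Homo sapiens), tested at 0.1 uM; on this read-out lower numbers stand for a weaker effect and higher numbers for a stronger effect at the one concentration tested. Compound 2 stands second highest of the three numbers. Its nearest neighbour is compound 1, whose number is lower but within the scatter of repeated measurements, so the two cannot be told apart on this read-out. The furthest is compound 3, whose number lies higher by an amount beyond the scatter.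

Compound 4, `NS(=O)(=O)Oc1ccc2c(c1)CN(C(=O)c1ccc(N3CCCCC3)cc1)CC2`, has not yet been measured in this assay. It differs from compound 2 in one place: hydrogen in place of piperidin-1-yl on a saturated ring carbon. The saturated ring that carried the piperidin-1-yl group now carries only hydrogen at that carbon.

Among the measured compounds shown here, no measured pair shows what such a removal does on this read-out, so the expectation rests on compound 2 alone. Compound 2 already gives a small number in this assay, and compound 1, with a different group on its aromatic ring, gives a number within the scatter of it. The step of a number 2.5 percentage points lower from compound 2 to compound 4 (within the scatter) is therefore expected to be small, with no clear direction beyond the scatter. For compound 4 the estimate in this assay is 6%, expected to fall between 0% and 16%.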

Compound 4, a percentage reported as inhibition, at one concentration (the size of the read-out at that concentration, not a potency): 11.5%
Compound 4: middle estimate off by 5.5 percentage points, on the low side; the measured number falls inside the stated range.
By their numbers in this assay, from the lowest: compounds 1, 2 and 4 (each within the scatter of the next); then compound 3.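

Replacing piperidin-1-yl with hydrogen on the saturated ring carbon, three ring bonds from the ring nitrogen, gives a number 3 percentage points higher from compound 2 to compound 4 (within the scatter) in this assay. This is the first pair shown that differs only at this carbon, and it removes a whole six-membered non-aromatic ring of 6 heavy atoms. Even so, the two compounds cannot be told apart on this read-out, so the pair gives no sign that piperidin-1-yl at this carbon adds to or takes from the effect at the one concentration tested.

No measured information shown here accounts for this result.

The compounds shown leave open whether a dimethylamino group, a hydroxyl group, a carboxylic acid or a longer carbon chain on that same saturated ring carbon would give a number beyond the scatter of compound 4. This read-out also gives the size of the effect at one concentration rather than a potency, so how compound 2 and compound 4 compare in potency remains an open question.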